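The compounds below may be only part of what the source reports. "The series", "measured", "known", "first", "only" and "open" are said of these compounds alone.

Compound 1, `C/C(C(=O)NC1CC1)=C(/C)c1ccc(Br)cc1`: 130 mg/kg in a toxicity assay on the whole organism (strain Icem-CET (SPF Caw)) for cytotoxicity, with Mus musculus as the target; a higher number here means that more compound is needed for the effect, a lower number that less compound is needed
Compound 2, `C=CCNC(=O)/C(C)=C(\C)c1ccc(Br)cc1`: 500 mg/kg in this assay
Compound 3, `C#CCNC(=O)/C(C)=C(\C)c1ccc(C)cc1`: 150 mg/kg in this assay

Among these three numbers compound 1 has the lowest one, though its gap to compound 3 lies within the scatter, so the two cannot be ordered; compound 2 stands clearly apart, with a 3.8-fold higher number from compound 1 to compound 2 (0.59 log units; beyond the scatter) following from allyl in place of cyclopropyl on an amide-type nitrogen.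

Compound 4, `C/C(C(=O)NC1CC1)=C(/C)c1ccccc1`, is not yet measured. It differs from compound 1 in one place: hydrogen in place of bromo on an aromatic carbon. Among the compounds with values here, none of the measured steps changes the aromatic ring, so no step bears directly on this one. Within the data shown here, the only nearby comparison is compound 3, which carries a methyl rather than a bromo on the ring but also a different group on the amide nitrogen, and its value sits within the scatter of compound 1; two changes at once make that comparison weak. With no direct evidence, no step beyond the scatter is expected from compound 1 to compound 4, and the estimate stays close to compound 1, that is a 1.2-fold higher number from compound 1 to compound 4 (0.09 log units; within the scatter). Compound 4 is therefore expected to give about 160 mg/kg, most likely between 75 mg/kg and 340 mg/kg.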

Compound 4, dose for half-maximal effect: 150 mg/kg
For compound 4 the middle estimate is 1.1-fold (0.03 log units) above the measured one; the range from low to high includes it.
By their numbers in this assay, from the lowest: compounds 1, 3 and 4 (each within the scatter of the next); then compound 2.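

In this assay, within the data shown here, hydrogen in place of bromo on an aromatic carbon gives a 1.2-fold higher number from compound 1 to compound 4 (0.06 log units; within the scatter), so the first single change on the ring in this set leaves no difference that can be told from the scatter. Among these compounds, at this carbon, para to a large group, the one heavy atom of the bromo can therefore leave without a readable shift, whereas the only earlier single step, on the amide-type nitrogen, is a 3.8-fold higher number from compound 1 to compound 2 (0.59 log units; beyond the scatter) and lies beyond the scatter. Nothing available gives a reason for this result.

Compound 3 carries a methyl on the ring but also differs on the amide-type nitrogen, so it cannot show whether other groups at this carbon, such as a methoxy, a nitrile or an amine, would behave as hydrogen and bromo do here. On these data alone, it also remains open whether the difference between cyclopropyl and allyl on the nitrogen persists with hydrogen on the ring, and how a longer chain at that nitrogen would compare.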